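A lactam-bearing chain replaces a carboxypyridine on the amide

The source may hold more compounds than are shown below. What is called first, only, known or untested is meant among the compounds shown, and "the series" means these compounds.

Of the compounds shown here, two built on the same core have been tested for how strongly they kill leukaemia cells. Compound 1 `C=C(CC)C(=O)c1ccc(OCC(=O)Nc2ccc(C(=O)O)cn2)c(Cl)c1Cl` carries a 5-carboxypyridin-2-yl group on its amide nitrogen. In a functional assay on CLL cells (Homo sapiens) for cytotoxicity, read by MTT assay, with a stated time of 48 h (on this read-out lower numbers stand for an effect already at smaller amounts and higher numbers for an effect only at larger amounts of compound), compound 1 gives 14900 nM, the highest of the two numbers recorded, meaning it needs the largest amount to show an effect. Compound 2 `C=C(CC)C(=O)c1ccc(OCC(=O)Nc2ccc(/C=C/C(=O)OCC)cc2)c(Cl)c1Cl` carries a different aromatic group there instead. In this assay compound 2 gives 1700 nM, a clearly lower number than compound 1, a gap that lies beyond the usual scatter.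

Compound 3 `C=C(CC)C(=O)c1ccc(OCC(=O)NCCCN2CCCC2=O)c(Cl)c1Cl` has not been measured. Compared with compound 1 the change is 3-(2-oxopyrrolidin-1-yl)propyl in place of 5-carboxypyridin-2-yl on an amide-type nitrogen. Within the data shown here, no measured pair shows this exact change, so its effect must be guessed. The expected step from compound 1 to compound 3 is a 2.5-fold lower number from compound 1 to compound 3 (0.40 log units; beyond the scatter), a moderate move towards a lower number, a little beyond the scatter but far from certain. On that basis compound 3 is estimated to give 6000 nM in this assay, with a likely range from 1500 nM to 25000 nM.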

Compound 3, half-maximal effective concentration: 13800 nM
For compound 3 the middle estimate is 2.3-fold (0.36 log units) below the measured one; measured number inside the range.
By their numbers in this assay, from the lowest: compound 2; then compounds 3 and 1 (each within the scatter of the next).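

In this assay the exchange of 5-carboxypyridin-2-yl for 3-(2-oxopyrrolidin-1-yl)propyl on the amide-type nitrogen amounts to a 1.1-fold lower number from compound 1 to compound 3 (0.03 log units; within the scatter) and leaves the two compounds indistinguishable. The two groups are built very differently, one a six-membered aromatic ring carrying a carboxylic acid and the other a five-membered non-aromatic ring on a propyl chain, so giving up the aromatic ring and the hydrogen-bond donor together brings no measurable gain, and compound 3 stays with compound 1, well apart from compound 2 at 1700 nM in this series. No measurement at hand explains why two such different groups read alike.

The compounds shown leave open how a simple amine in place of the 2-oxopyrrolidin-1-yl ring, or a longer chain carrying that same ring, would read at this nitrogen. They also leave open whether the lower number of compound 2 goes with its benzene ring or with its ethyl ester, which a benzene ring carrying a carboxylic acid could help to separate.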